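A few compounds are considered here, and "the series" means these few. Any claim that something is new, unique, unknown or untested is made for them only; others in the source may bear on it.

Three compounds make up this small set: compound 1 `O=C(NCCCCc1ccc(-c2ccc(-c3cccs3)s2)s1)c1cc(F)cc(C(F)(F)F)c1`, compound 2 `O=C(NCCCCc1ccc(-c2cccs2)s1)c1cc(F)cc(C(F)(F)F)c1` and compound 3 `O=C(NCCCCc1cccs1)c1cc(F)cc(C(F)(F)F)c1`. In an ADME assay on MDCK cells (Canis lupus familiaris) for cytotoxicity, read by MTT assay, with a stated time of 2 days (a lower number here means that less compound is tolerated, a higher number that more compound is tolerated), compound 1 has no usable result, its entry reading "not determined" (no result reported). Within the data shown here, compound 2 gives 27400 nM, which makes it the only compound with a number, so there is nothing to rank it against. Going on to compound 3 alters one place: hydrogen in place of thiophen-2-yl on an aromatic carbon. Among the measured compounds shown here, no pair of measured compounds shows what a change of this kind does in this assay, so the size of the step cannot be read from the data and has to be judged. With compound 2 at 27400 nM as the only anchor, a moderate move towards more compound tolerated is expected, perhaps not far beyond the usual scatter, and the range has to stay wide. The expected change is a 1.8-fold higher number from compound 2 to compound 3 (0.26 log units; within the scatter). For compound 3 the estimate is 50000 nM, with an expected range of 18000 nM to 150000 nM.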

Compound 3, half-maximal cytotoxic concentration: 43500 nM
For compound 3 the middle estimate is 1.1-fold (0.06 log units) above the measured one, within the range that was stated.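

In this assay this position now has its first readable step, a 1.6-fold higher number from compound 2 to compound 3 (0.20 log units; within the scatter), so replacing thiophen-2-yl with hydrogen on the aromatic carbon next to the ring sulfur leaves the read-out within the scatter. Losing the 5 heavy atoms and the whole five-membered aromatic ring of that group therefore makes no difference that this pair can resolve, and compound 2 and compound 3 cannot be placed in an order of tolerance. The data offer no measurement that would explain why this change leaves the two results so close.

Going by these compounds, compound 1 gives "not determined" (no result reported), so the steps that would link it to the other two compounds cannot be read, and it remains unknown whether the pattern holds once the substituent at this position grows beyond a single thiophen-2-yl. Also open, on these data alone, is whether an amine or a carboxylic acid on this same aromatic carbon would stay as close to hydrogen and thiophen-2-yl as those two stay to each other.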